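Dimethylamino for imidazolyl on a butynyl-linked lactam pair

This account rests on a few compounds, and the source may have more. Where it says the series, first, only, none or still open, it means among the compounds named here.

Measured so far:
compound 1, `CC1CCC(=O)N1CC#CCn1ccnc1`, > 100 mg/kg
compound 2, `CC1CCC(=O)N1CC#CCN(C)C`, 1.7 mg/kg
compound 3, `O=C1NCCN1CC#CCn1ccnc1`, > 100 mg/kg

The three compounds were tested in a functional assay on the whole organism for agonist activity, with Mus musculus as the target; on this read-out lower numbers stand for an effect already at smaller amounts and higher numbers for an effect only at larger amounts of compound. In this assay compound 1 gives > 100 mg/kg, which is a limit of the assay and not a number. Compound 2, which carries dimethylamino in place of 1H-imidazol-1-yl on a saturated chain carbon bound to a triple-bonded carbon, gives 1.7 mg/kg in this assay. The step of an at least 58-fold lower number from compound 1 to compound 2 (1.76 log units; beyond the scatter) is therefore large. Whether more lies behind it cannot be said, since the limit of > 100 mg/kg in this assay, at which 2 of the 3 values shown sit, caps what the assay reports for compound 1.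

Compound 3 shares the acetylenic linker but rests on a different core; the difference between the two cores is not broken down here. In this assay compound 3 gives > 100 mg/kg, again a limit of the assay rather than a number.

Compound 4, `CN(C)CC#CCN1CCNC1=O`, has not yet been measured. It differs from compound 3 by dimethylamino in place of 1H-imidazol-1-yl on a saturated chain carbon bound to a triple-bonded carbon, which is the same change, at the same place, as that between compound 1 and compound 2, occurring twice among these compounds. The expected step is estimated as an at least 16-fold lower number from compound 3 to compound 4 (1.22 log units; beyond the scatter), an estimate that rests on an at least 58-fold lower number from compound 1 to compound 2 (1.76 log units; beyond the scatter) and on nothing more, since compound 3 offers only a limit as a starting point. Compound 4 is thus expected to give about 6 mg/kg in this assay, with a plausible range from 1.5 mg/kg to 60 mg/kg.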

Compound 4, dose for half-maximal effect: 9.7 mg/kg
The estimate for compound 4 lay 1.6-fold (0.21 log units) below the measured number, and the stated range covers the measured number.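

Placing dimethylamino in place of 1H-imidazol-1-yl on a saturated chain carbon bound to a triple-bonded carbon on the second core gives, in this assay, an at least 10-fold lower number from compound 3 to compound 4 (1.01 log units; beyond the scatter). The change thus goes the same way and is large on both cores shown, but these two cases do not establish whether its size carries over from one core to the other: the same change on two cores in this assay, an at least 58-fold lower number (1.76 log units; beyond the scatter) from compound 1 to compound 2 and an at least 10-fold lower number (1.01 log units; beyond the scatter) from compound 3 to compound 4; the limit leaves it open whether they differ Each step starts from a limit of the assay and not a number, so neither gives the full size of the change on its core, and the measured values of compound 2 and compound 4 are the only firm numbers in the set: the limit of > 100 mg/kg in this assay, at which 2 of the 4 values shown sit.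

The compounds shown leave open whether this gain belongs to dimethylamino in particular or would also appear with another amine, such as diethylamino, on the same chain carbon. They also leave open whether the change would hold with a longer chain in place of the butynyl linker, or on a core other than the two seen here.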